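The source may report more compounds than this note shows. Statements on the series, on what has been measured and on what is new or still open speak of the compounds shown alone.

Measured so far:
compound 1, `ClCc1cccc(Cn2cnc3c(Cl)ncnc32)c1`: 8910 nM
compound 2, `ClCc1cccc(Cn2cnc3c(Cl)nc(Cl)nc32)c1`: 40700 nM
compound 3, `ClCc1ccccc1Cn1cnc2ncnc(Cl)c21`: > 100000 nM

These values come from a functional assay on NCI-H226 cells (Homo sapiens) for cytotoxicity, read by sulforhodamine B assay, with a stated time of 48 h; a higher number here means that more compound is tolerated, a lower number that less compound is tolerated. From compound 1 to compound 2 the change is chloro in place of hydrogen on an aromatic carbon, and it gives a 4.6-fold higher number from compound 1 to compound 2 (0.66 log units; beyond the scatter). For compound 3 the value is only a limit of the limit of > 100000 nM in this assay, at which 1 of the 3 values shown sits, not a number. The difference between the core of compound 3 and the core of compound 1 is not broken down here.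

Compound 4, `ClCc1ccccc1Cn1cnc2nc(Cl)nc(Cl)c21`, has not been measured. It differs from compound 3 by chloro in place of hydrogen on an aromatic carbon, the same change as that from compound 1 to compound 2. Since compound 3 already sits at a limit, and the same change raised the number in the earlier pair, compound 4 is expected to stay at or beyond that limit, a step estimated as a step that the limit leaves unreadable from compound 3 to compound 4. For compound 4 the estimated value is 300000 nM, between 100000 nM and 1000000 nM.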

Compound 4, concentration lethal to 50% of the cells: 28200 nM
Compound 4: middle estimate off by 11-fold (1.03 log units), on the high side; the whole stated range lies above it.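

In this assay, as far as these compounds go, chloro in place of hydrogen on an aromatic carbon gives an at least 3.5-fold lower number from compound 3 to compound 4 (0.54 log units; beyond the scatter), and so the change does not carry over from one core to the other with the same direction: the same change on two cores in this assay, a 4.6-fold higher number (0.66 log units; beyond the scatter) from compound 1 to compound 2 and an at least 3.5-fold lower number (0.54 log units; beyond the scatter) from compound 3 to compound 4, at least 16-fold (1.20 log units) apart, beyond the scatter of two such steps Compound 3 gives > 100000 nM, which is a limit and not a number, so the full size of this step stays unknown. The two pairs show that the outcome of this change differs between these two cores, but they do not show why, and they set no rule for other cores in the series.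

The compounds shown leave open how an amine or a methoxy group would behave in place of this chloro, between two ring nitrogen atoms, on either core. They also leave open whether a bromo group there would show the same split between the two cores.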